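Aryl swap on sulfur in the benzamide series

The source may hold more compounds than are shown below. What is called first, only, known or untested is meant among the compounds shown, and "the series" means these compounds.

Compound 2 `Cc1ccc(SCc2ccc(C(=O)Nc3ccccc3N)cc2)cc1` stands highest of the three numbers in a functional assay on HCT-116 cells (Homo sapiens) for inhibition, read by CCK-8 assay, with a stated time of 72 h, tested at 8 uM; on this read-out higher numbers stand for more inhibition of growth at the one concentration tested and lower numbers for less inhibition of growth: compound 2 gives 84%. Compound 1 `COc1ccc(SCc2ccc(/C=C/C(=O)Nc3ccccc3N)cc2)cc1OC` gives 49.5%, and compound 3 `Nc1ccccc1NC(=O)/C=C/c1ccc(CSc2cccc3ccccc23)cc1` gives 35.2%; both share a core different from that of compound 2. Compound 4 `Nc1ccccc1NC(=O)c1ccc(CSc2ccc(Cl)cc2)cc1` differs from compound 2 by chloro in place of methyl on an aromatic carbon. Within the data shown here, the only measured step on the group attached to sulfur is a number 14.3 percentage points lower from compound 1 to compound 3 (beyond the scatter), a whole-aryl exchange on the other core, so it bears only loosely on a single-substituent swap. Among the measured compounds shown here, no measured pair isolates chloro against methyl. The expected step is a number 6 percentage points lower from compound 2 to compound 4 (within the scatter), likely within the scatter. Compound 4 is therefore estimated at 78%, with a range from 60% to 92%.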

Compound 4, percent growth inhibition at one concentration: 76.6%
The estimate for compound 4 lay 1.4 percentage points above the measured number; measured number inside the range.
By their numbers in this assay, from the lowest: compound 3; then compound 1; then compounds 4 and 2 (each within the scatter of the next).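

Going from 4-methylphenyl to 4-chlorophenyl on the sulfur, this assay gives a number 7.4 percentage points lower from compound 2 to compound 4 (within the scatter) and so shows that this position, para to a large group, tolerates chloro in place of methyl on the shared core. This is the only single-substituent swap shown on this aryl group, whereas the step between compound 1 and compound 3 exchanged the whole aryl group on another core. No measurement shown here explains the result.

On these data alone, whether an amine or a carboxylic acid at the same place keeps this level of inhibition remains open. Also open, as far as these compounds go, is whether chloro in place of methyl reads the same on the core of compound 1.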